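Working notes on the ring-amine substituent series

A few compounds are considered here, and "the series" means these few. Any claim that something is new, unique, unknown or untested is made for them only; others in the source may bear on it.

Measured compounds:
compound 1 `Nc1scc(CN2CCN(c3ccncc3)CC2)c1C(=O)c1ccc(Cl)cc1` — 1.4%
compound 2 `Nc1scc(CN2CCN(CCCc3ccc(Cl)cc3)CC2)c1C(=O)c1ccc(Cl)cc1` — -3%

In a functional assay on CHO cells with adenosine receptor A1 (Homo sapiens) as the target, read by cAMP accumulation and immunoassay, with a stated time of 6 min, tested at 0.1 uM (on this read-out higher numbers stand for a weaker effect at the one concentration tested and lower numbers for a stronger effect), compound 1 gives 1.4% and compound 2 gives -3%. The one measured step, a number 4.4 percentage points lower from compound 1 to compound 2 (within the scatter), lies within the scatter, so on the numbers shown compound 2 stands lowest of the two only nominally; its nearest neighbour, compound 1, cannot be told apart from it.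

Compound 3 `Nc1scc(CN2CCN(c3cc(Cl)ccc3Cl)CC2)c1C(=O)c1ccc(Cl)cc1` is not yet measured. The change from compound 2 is 2,5-dichlorophenyl in place of 3-(4-chlorophenyl)propyl on an amine nitrogen in a ring. For the measured compounds named here, the only step that bears on this position, a number 4.4 percentage points lower from compound 1 to compound 2 (within the scatter), exchanged an aromatic ring bound directly to the ring nitrogen for a chain-linked aromatic ring and moved nothing beyond the scatter. Compound 3 returns to an aromatic ring bound directly to the ring nitrogen, as in compound 1 whose value is 1.4%. No step beyond the scatter is therefore expected in this assay; the expected step is a number 3 percentage points higher from compound 2 to compound 3 (within the scatter). For compound 3 the estimate in this assay is 0%, with a range from -12% to 12%.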

Compound 3, a percentage reported as activity, at one concentration (the size of the read-out at that concentration, not a potency): -6.2%
The estimate for compound 3 lay 6.2 percentage points above the measured number; measured number inside the range.
By their numbers in this assay, from the lowest: compounds 3, 2 and 1 (each within the scatter of the next).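

In this assay, 2,5-dichlorophenyl on the amine nitrogen in the ring adds a third substituent that the read-out does not separate from the other two: the change gives a number 3.2 percentage points lower from compound 2 to compound 3 (within the scatter), and the comparison with the pyridin-4-yl compound gives a number 7.6 percentage points lower from compound 1 to compound 3 (within the scatter). The earlier pair compared only pyridin-4-yl with 3-(4-chlorophenyl)propyl, whereas these steps extend the flat result to an aromatic ring of carbon only that carries two chlorines, so pyridin-4-yl, 3-(4-chlorophenyl)propyl and 2,5-dichlorophenyl cannot be told apart at this position in this read-out. No supporting measurement is available to explain why these substituents cannot be told apart.

With a read-out at one concentration only, these compounds cannot be ranked by potency, and any potency differences among them remain hidden. Going by these compounds, it also remains open whether a carboxylic acid or a primary amine on the chain of the 3-(4-chlorophenyl)propyl group, or a longer chain at the same nitrogen, would give a step beyond the scatter in this assay.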